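A few compounds are considered here, and "the series" means these few. Any claim that something is new, unique, unknown or untested is made for them only; others in the source may bear on it.

Two measured compounds frame this step. Among the compounds with values here, compound 1 `Cc1ccc(-c2nc3cc(-c4nc5cc(C#N)ccc5[nH]4)ccc3[nH]2)cc1` and compound 2 `CN1CCN(c2ccc3[nH]c(-c4ccc5[nH]c(-c6ccccc6)nc5c4)nc3c2)CC1` share a core and differ in two places at once, so no single step between them can be read. In a functional assay on RPMI 8402 cells (Homo sapiens) for cytotoxicity (a higher number here means a weaker inhibitor, a lower number a stronger inhibitor), compound 2 gives 490 nM; in this assay compound 1 gives 570 nM. The two numbers lie within the scatter of each other, so neither compound can be set apart from the other on this assay.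

Compound 3 `Cc1ccc(-c2nc3cc(-c4nc5cc(N6CCN(C)CC6)ccc5[nH]4)ccc3[nH]2)cc1` is the next compound in line. Against compound 2 it carries one change: methyl in place of hydrogen on an aromatic carbon. Within the data shown here, no measured pair isolates this change, so there is nothing to compare it against directly.

The expectation for compound 3 is a step from compound 2 that stays within the scatter, a 1.1-fold lower number from compound 2 to compound 3 (0.04 log units; within the scatter). For compound 3 the estimated value in this assay is 450 nM, with a range from 180 nM to 1100 nM.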

Compound 3, half-maximal inhibitory concentration: 830 nM
The estimate for compound 3 lay 1.8-fold (0.27 log units) below the measured number, within the range that was stated.
By their numbers in this assay, from the lowest: compounds 2, 1 and 3 (each within the scatter of the next).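

In this assay, phenyl to 4-methylphenyl, with the methyl on the aromatic carbon para to a large group, reads as a 1.7-fold higher number from compound 2 to compound 3 (0.23 log units; within the scatter) and so leaves the hydrogen and methyl forms not set apart at this position. With 4-methylphenyl held in place, 4-methylpiperazin-1-yl in place of cyano reads as a 1.5-fold higher number from compound 1 to compound 3 (0.16 log units; within the scatter) and so leaves these two groups not set apart on this read-out either. No supporting data bear on either step.

Only hydrogen and methyl are shown at the para position, so it remains open whether a methoxy group or a carboxylic acid there would give a step beyond the scatter. At the other site, only nitrile and 4-methylpiperazin-1-yl are shown, which leaves the effect of a primary amine or a morpholine group unknown.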